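An Anilino Group in Place of the Fluorophenyl

The compounds below may be only part of what the source reports. "The series", "measured", "known", "first", "only" and "open" are said of these compounds alone.

Compound 1 `COc1cc(C(=O)c2sc3ccccc3c2-c2ccc(F)cc2)cc(OC)c1OC` gives 3200 nM in a functional assay on A549 cells (Homo sapiens) for antiproliferative activity, read by MTT assay, with a stated time of 72 h; a higher number here means a weaker inhibitor, a lower number a stronger inhibitor.
Compound 2 `COc1ccc(OC)c(-c2c(C(=O)c3cc(OC)c(OC)c(OC)c3)sc3ccccc23)c1` gives > 10000 nM in this assay, which is a limit of the assay rather than a number.
Compound 3 `COc1ccc(-c2c(C(=O)c3cc(OC)c(OC)c(OC)c3)sc3ccccc23)cc1C` gives > 10000 nM in this assay, likewise only a limit.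

Compound 1 thus stands as the only one of the three with a measured number. The other two values sit at the limit of > 10000 nM in this assay, at which 2 of the 3 values shown sit. Compound 4 `COc1cc(C(=O)c2sc3ccccc3c2Nc2ccccc2)cc(OC)c1OC` has not yet been measured; it differs from compound 1 by anilino in place of 4-fluorophenyl on an aromatic carbon. Among the compounds with values here, no measured step puts an anilino group in this position, but two steps exchange the 4-fluorophenyl of compound 1 for other aromatic groups: an at least 3.1-fold higher number from compound 1 to compound 2 (0.49 log units; beyond the scatter) and an at least 3.1-fold higher number from compound 1 to compound 3 (0.49 log units; beyond the scatter). Both are at least modest weakenings. Since every exchange of the 4-fluorophenyl seen so far has weakened inhibition, a weakening is expected here as well, though its size is uncertain. Compound 4 is therefore estimated at 8000 nM, in a range from 2000 nM to 30000 nM. That estimate means an expected 2.5-fold higher number from compound 1 to compound 4 (0.40 log units; beyond the scatter).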

Compound 4, half-maximal inhibitory concentration: 3000 nM
Estimate against measurement, compound 4: 2.7-fold (0.43 log units) above; the range from low to high includes it.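

Anilino is the first group in place of the 4-fluorophenyl that leaves the result within the scatter: a 1.1-fold lower number from compound 1 to compound 4 (0.03 log units; within the scatter). This position therefore does not reject every exchange of the 4-fluorophenyl, and a ring attached through the anilino nitrogen can serve here as well as the 4-fluorophenyl does. Anilino also separates clearly from the 4-methoxy-3-methylphenyl and 2,5-dimethoxyphenyl groups, with an at least 3.3-fold lower number from compound 3 to compound 4 (0.52 log units; beyond the scatter) and an at least 3.3-fold lower number from compound 2 to compound 4 (0.52 log units; beyond the scatter), though both sizes are only minimum sizes because compound 2 and compound 3 rest on a limit of the assay rather than a number: the limit of > 10000 nM in this assay, at which 2 of the 4 values shown sit.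

The compounds shown do not tell whether a plain phenyl, a benzyl or a 4-fluoroanilino group here would stay level with compound 1 and compound 4. Nor do they show how substituents on the anilino ring would act.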